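Cytotoxicity notes on the acetamido-to-ethoxy step

A few compounds are considered here, and "the series" means these few. Any claim that something is new, unique, unknown or untested is made for them only; others in the source may bear on it.

Compound 1 `CC(=O)Nc1cccc(-c2ccc(C(=O)N(Cc3cccc(OCCCCCC(=O)O)c3)C(C)C)cc2)c1` is the acid member of the set. In an ADME assay on HepG2 cells (Homo sapiens) for cytotoxicity, read by CellTiter-Glo and resazurin assay, with a stated time of 72 h (on this read-out higher numbers stand for an effect only at larger amounts of compound and lower numbers for an effect already at smaller amounts), compound 1 returns only a limit, > 26000 nM. Compound 2 `CC(C)N(Cc1cccc(OCCCCCC(=O)O)c1)C(=O)c1ccc(-c2cccc(S(C)(=O)=O)c2)cc1` carries methylsulfonyl in place of acetamido on an aromatic carbon. In this assay compound 2 likewise returns a limit, > 26000 nM. Compound 3 `CCOC(=O)CCCCCOc1cccc(CN(C(=O)c2ccc(-c3cccc(NC(C)=O)c3)cc2)C(C)C)c1` has ethyl in place of hydrogen on an oxygen next to a carbonyl group. In this assay compound 3 also returns a limit, > 26000 nM. Both measured steps are consequently unreadable in size: a step that the two limits leave unreadable from compound 1 to compound 2 and a step that the two limits leave unreadable from compound 1 to compound 3. Compound 3 thus stands at the common ceiling of the series, (the limit of > 26000 nM in this assay, at which 3 of the 3 values shown sit).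

Compound 4 `CCOC(=O)CCCCCOc1cccc(CN(C(=O)c2ccc(-c3cccc(OCC)c3)cc2)C(C)C)c1` differs from compound 3 by ethoxy in place of acetamido on an aromatic carbon. Within the data shown here, no measured step bears directly on this change, and the two steps that do exist give no readable size. Given that every value sits at the limit, the step from compound 3 is expected to be about a step that the limit leaves unreadable from compound 3 to compound 4, none beyond the scatter. Compound 4 is estimated at 30000 nM, within 15000 nM to 60000 nM, most likely reported again as a limit.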

Compound 4, half-maximal effective concentration: > 22300 nM
Compound 4 gave a limit, no number; the forecaster's own chance of this, stated with the estimate: 80%; the middle value does not contradict the limit.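

Compound 4 returns only a limit (> 22300 nM) and compound 3 also stands as a limit, so the step between them cannot be read. The compounds shown leave open where any of them reaches a half-maximal effect, and whether ethoxy in place of acetamido shifts that concentration at all.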